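The source may hold more compounds than are shown below. What is called first, only, known or untested is meant among the compounds shown, and "the series" means these compounds.

Measured compounds:
compound 1, `COc1cc2c(Nc3cccc(F)c3F)ncnc2c(OC)c1OC`: in a functional assay on SGC-7901 cells (Homo sapiens) for antiproliferative activity, read by MTT assay, with a stated time of 72 h (a lower number here means a stronger inhibitor, a higher number a weaker inhibitor), only a limit, > 30000 nM
compound 2, `COc1cc2c(Nc3cccc(Br)c3F)ncnc2c(OC)c1OC`: in this assay only a limit, > 30000 nM
compound 3, `COc1cc2c(Nc3ccc(F)c(Cl)c3)ncnc2c(OC)c1OC`: in this assay 5420 nM

Going by the values given here, compound 3 gives the only number in the set; the other two values sit at the limit of > 30000 nM in this assay, at which 2 of the 3 values shown sit. The next compound, compound 4 `COc1cc2c(Nc3ccc(Br)c(F)c3)ncnc2c(OC)c1OC`, differs from compound 3 in one place: 4-bromo-3-fluorophenyl in place of 3-chloro-4-fluorophenyl on a nitrogen on an aromatic ring. The steps measured so far that bear on it both reach compound 3 from a limit: an at least 5.5-fold lower number from compound 1 to compound 3 (0.74 log units; beyond the scatter) and an at least 5.5-fold lower number from compound 2 to compound 3 (0.74 log units; beyond the scatter); between the two limits the step that the two limits leave unreadable from compound 1 to compound 2 cannot be read. Neither step shows what exchanging chloro for bromo and moving the fluoro within the same aryl does by itself, so no step beyond the scatter is expected in this assay, in either direction. Compound 4 is thus estimated at 5000 nM, between 2000 nM and 15000 nM, a step of a 1.1-fold lower number from compound 3 to compound 4 (0.04 log units; within the scatter) that is expected to stay within the scatter.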

Compound 4, half-maximal inhibitory concentration: > 30000 nM
Compound 4 ended at the assay's limit; the forecaster's own chance of this, stated with the estimate: 10%; at least 6.0-fold (0.77 log units) between middle value and limit.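

In this assay the group on the nitrogen proves sensitive to a change among halogen-bearing aryl groups: 4-bromo-3-fluorophenyl in place of 3-chloro-4-fluorophenyl gives an at least 5.5-fold higher number from compound 3 to compound 4 (0.74 log units; beyond the scatter) and no measurable number for compound 4. Among the aryl groups shown, only 3-chloro-4-fluorophenyl gives a number, and the steps among compound 1, compound 2 and compound 4 cannot be read: the limit of > 30000 nM in this assay, at which 3 of the 4 values shown sit.

The step changes the halogen and the place of the fluoro together and does not separate the two. Going by these compounds, how an amine or a nitrile on this aryl group would read remains open.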